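The source may hold more compounds than are shown below. What is called first, only, known or untested is meant among the compounds shown, and "the series" means these compounds.

Working notes on the series.

Compound 1 `COc1ccc(-c2sc(C(=O)O)cc2-c2cc(OC)c(OC)c(OC)c2)cc1[N+](=O)[O-]` is the reference point in a functional assay on SGC-7901 cells (Homo sapiens) for antiproliferative activity, read by MTT assay, with a stated time of 72 h; a higher number here means a weaker inhibitor, a lower number a stronger inhibitor; there compound 1 gives 23300 nM. Compound 2 `COc1ccc(-c2sc(C(=O)O)cc2-c2cc(OC)c(OC)c(OC)c2)cc1OCc1ccccc1` carries the change counted as benzyloxy in place of nitro on an aromatic carbon. For compound 2 this assay reports only a limit, > 100000 nM. The step of an at least 4.2-fold higher number from compound 1 to compound 2 (0.63 log units; beyond the scatter) is accordingly itself a limit, resting on (the limit of > 100000 nM in this assay, at which 1 of the 3 values shown sits).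

Compound 3 `COc1ccc(-c2sccc2-c2cc(OC)c(OC)c(OC)c2)cc1[N+](=O)[O-]` differs from compound 1 in the core by the change counted as hydrogen in place of carboxy on an aromatic carbon. In this assay compound 3 gives 3310 nM. Within the data shown here, the step of a 7.0-fold lower number from compound 1 to compound 3 (0.85 log units; beyond the scatter) leaves compound 3 with the lowest number of the two numbers measured so far.

Compound 4 `COc1ccc(-c2sccc2-c2cc(OC)c(OC)c(OC)c2)cc1OCc1ccccc1` has not yet been measured. It differs from compound 3 by benzyloxy in place of nitro on an aromatic carbon. This is the same change that was made from compound 1 to compound 2, and the place is described in the same words for both pairs, so it is treated as the same change carried onto the core of compound 3. Among the measured compounds shown here, the only guide to its size is the earlier step of an at least 4.2-fold higher number from compound 1 to compound 2 (0.63 log units; beyond the scatter), which is a limit and gives no more than a floor. On that basis the step from compound 3 to compound 4 is expected to be a 6.0-fold higher number from compound 3 to compound 4 (0.78 log units; beyond the scatter). Compound 4 is accordingly estimated at 20000 nM, with a range of 8000 nM to 100000 nM, and a real chance that this assay will again report only a limit for compound 4.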

Compound 4, half-maximal inhibitory concentration: > 100000 nM
Compound 4: no number, only a limit; the forecaster's own chance of this, stated with the estimate: 25%; middle value at least 5.0-fold (0.69 log units) from the limit.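

In this assay compound 4 gives only a limit, > 100000 nM, and not a number. Benzyloxy in place of nitro on the core of compound 3 gives an at least 30-fold higher number from compound 3 to compound 4 (1.48 log units; beyond the scatter), so the change moves the number the same way on both cores, although only floors can be set side by side: the same change on two cores in this assay, an at least 4.2-fold higher number (0.63 log units; beyond the scatter) from compound 1 to compound 2 and an at least 30-fold higher number (1.48 log units; beyond the scatter) from compound 3 to compound 4; the limit leaves it open whether they differ. This does not show that the change has the same size on the two cores, or a different one, and the step between compound 2 and compound 4 cannot be read, because both benzyloxy compounds rest on a limit: the limit of > 100000 nM in this assay, at which 2 of the 4 values shown sit.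

Only nitro and benzyloxy are shown at this place, on either core, so it stays open how an amine, a hydroxy group or a short alkoxy group such as ethoxy would read there, and whether any of them would give a number rather than a limit. The carboxy group is compared only with hydrogen, and only with nitro in place, which leaves open how a methyl ester or a primary amide would read on the shared core.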